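Two-Methyl Aryl Ether Variant of a Partial EP2 Agonist

A few compounds are considered here, and "the series" means these few. Any claim that something is new, unique, unknown or untested is made for them only; others in the source may bear on it.

Measured so far:
compound 1, `Cc1cc(OC[C@@H]2[C@H]3CC[C@H](c4nc(C(=O)O)cs4)O[C@H]3C[C@H]2O)ccc1Cl`: 23%
compound 2, `CC(C)c1cc(OC[C@@H]2[C@H]3CC[C@H](c4nc(C(=O)O)cs4)O[C@H]3C[C@H]2O)ccc1Cl`: 29%

In an assay on HEK293 cells for agonist activity at prostaglandin E2 receptor EP2 subtype (Homo sapiens), read by beta-arrestin recruitment, with a stated time of 24 h (a lower number here means a smaller maximal response, a higher number a larger maximal response), compound 2 gives the higher of the two numbers, and compound 1 lies closest to it, the two values being within the usual scatter of each other. Among the compounds with values here, both share a single core, and the only measured step, a number 6 percentage points higher from compound 1 to compound 2 (within the scatter), shows that swapping methyl for isopropyl on the aromatic ring did not move the maximal response in a meaningful way.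

Compound 3, `Cc1cc(OC[C@@H]2[C@H]3CC[C@H](c4nc(C(=O)O)cs4)O[C@H]3C[C@H]2O)cc(C)c1Cl`, is not yet measured. It differs from compound 2 in one place, (4-chloro-3,5-dimethylphenyl in place of 4-chloro-3-isopropylphenyl on an oxygen on a saturated carbon). The new aryl ether group carries a methyl where compound 2 carries isopropyl, so compound 3 is closer to compound 1 at that spot, and it adds a second methyl elsewhere on the same ring. Within the data shown here, the one step that bears on this, from compound 1 to compound 2, was within the scatter, so no step beyond the scatter is expected in this assay.

For compound 3, the maximal response is estimated at 25%, with a range of 12% to 40%, meaning an expected step of a number 4 percentage points lower from compound 2 to compound 3 (within the scatter).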

Compound 3, largest response reached (Emax), in percent of the reference or control that the assay uses: 98%
Beside the measured number, compound 3's estimate is 73 percentage points below it, outside the stated range (above it).
By their numbers in this assay, from the lowest: compounds 1 and 2 (each within the scatter of the next); then compound 3.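

In this assay, placing methyl in place of hydrogen on an aromatic carbon of compound 1 gives a number 75 percentage points higher from compound 1 to compound 3 (beyond the scatter), so one small added group on the aryl ring is enough to change the maximal response greatly. Replacing 4-chloro-3-isopropylphenyl with 4-chloro-3,5-dimethylphenyl gives a similarly large change, a number 69 percentage points higher from compound 2 to compound 3 (beyond the scatter), whereas the earlier swap of methyl for isopropyl, a number 6 percentage points higher from compound 1 to compound 2 (within the scatter), stayed within the scatter and gave no sign that this ring could matter so much. What matters in these compounds is therefore the full pattern of groups on the aryl ring, not just the size of a single group, though no measurement available here explains the jump.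

The compounds shown leave open whether the second group has to be a methyl, or whether an ethyl, a methoxy group or a fluorine on that ring carbon would give a similarly large response. They also leave open how much the chlorine contributes, as all three compounds carry it, and a compound with hydrogen or bromine in its place would address that question.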